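The compounds below may be only part of what the source reports. "The series", "measured", "known", "first", "only" and "open" are said of these compounds alone.

In a functional assay on PC-12 cells (Rattus norvegicus) for inhibition, read by sulforhodamine B assay (a lower number here means a stronger inhibitor, a higher number a weaker inhibitor), compound 1 (`O=C1N=C(O)S/C1=C\c1ccc(OCC2CCCCO2)cc1`) gives 22000 nM and compound 3 (`CC(C)COc1ccc(/C=C2\SC(=O)NC2=O)cc1`) gives 16000 nM as measured values. Compound 2 (`O=C1NC(=O)C(Cc2ccc(OCC3CCC3)cc2)S1`) stands at > 100000 nM in this assay which is a limit and not a number. Compound 4 (`CCCOc1ccc(CC2SC(=O)NC2=O)cc1`) awaits measurement and differs from compound 2 by ethyl in place of cyclobutyl on a saturated chain carbon bound to an oxygen on an aromatic ring in one place: ethyl in place of cyclobutyl on a saturated chain carbon bound to an oxygen on an aromatic ring. Within the data shown here, no step between measured compounds sizes this change, so the step expected in this assay is modest, toward a stronger inhibitor if it exceeds the scatter at all. The estimated at least 1.2-fold lower number from compound 2 to compound 4 (0.09 log units; that floor lies within the scatter) starts from that limit and is expected to stay small. Compound 4 is expected at 80000 nM in this assay with an estimated range from 30000 nM to 130000 nM across repeated measurements.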

Compound 4, half-maximal inhibitory concentration: 45000 nM
Beside the measured number, compound 4's estimate is 1.8-fold (0.25 log units) above it, within the range that was stated.
By their numbers in this assay, from the lowest: compounds 3 and 1 (each within the scatter of the next); then compound 4. At a limit, above all of these: compound 2.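

In this assay, the swap of cyclobutyl for ethyl on a saturated chain carbon bound to an oxygen on an aromatic ring gives an at least 2.2-fold lower number from compound 2 to compound 4 (0.34 log units; beyond the scatter), the first sign that this position responds beyond the scatter. Compound 2 stands at > 100000 nM, which is a limit and not a number. The step is therefore only a floor, and its full size stays unknown: the limit of > 100000 nM in this assay, at which 1 of the 4 values shown sits.

The compounds shown leave open how a longer chain, an amine or a carboxylic acid would read at this place. They also leave open whether ethyl in place of cyclobutyl would act alike on the core of compound 3.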